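Trifluoromethyl in place of chloro on the pendant phenyl

The source may report more compounds than this note shows. Statements on the series, on what has been measured and on what is new or still open speak of the compounds shown alone.

Compound 1 `CC(=O)Nc1cccc(C2CCN(CCCn3c(-c4ccccc4)nc4ccccc43)CC2)c1`: 2 nM
Compound 2 `CC(=O)Nc1cccc(C2CCN(CCCn3c(-c4ccccc4Cl)nc4ccccc43)CC2)c1`: 10 nM
Compound 3 `CC(=O)Nc1cccc(C2CCN(CCCn3c(-c4cccc(Cl)c4)nc4ccccc43)CC2)c1`: 5 nM

In an assay for displacement of a labelled ligand from melanin-concentrating hormone receptor 1 (Homo sapiens), read by fluorescence (on this read-out lower numbers stand for stronger inhibition and higher numbers for weaker inhibition), compound 3 gives 5 nM and holds the second highest of the three numbers. It stands within the scatter of compound 2 (a 2.0-fold lower number from compound 2 to compound 3 (0.30 log units; within the scatter)) but beyond the scatter from compound 1 (a 2.5-fold higher number from compound 1 to compound 3 (0.40 log units; beyond the scatter)). Compound 4 `CC(=O)Nc1cccc(C2CCN(CCCn3c(-c4ccccc4C(F)(F)F)nc4ccccc43)CC2)c1` differs from it by 2-(trifluoromethyl)phenyl in place of 3-chlorophenyl on an aromatic carbon. The step that bears most on this is a 5.0-fold higher number from compound 1 to compound 2 (0.70 log units; beyond the scatter), since the 2-chlorophenyl of compound 2 and the 2-(trifluoromethyl)phenyl of compound 4 are substituted alike, and a 2.5-fold higher number from compound 1 to compound 3 (0.40 log units; beyond the scatter) shows that any chloro on the phenyl raised the number. Compound 4 is therefore expected to give a higher number than compound 3 (a 4.0-fold higher number from compound 3 to compound 4 (0.60 log units; beyond the scatter)). Compound 4 is estimated at 20 nM with a range from 6 nM to 60 nM.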

Compound 4, half-maximal inhibitory concentration: 50 nM
Compound 4: middle estimate off by 2.5-fold (0.40 log units), on the low side; the range from low to high includes it.
By their numbers in this assay, from the lowest: compound 1; then compounds 3 and 2 (each within the scatter of the next); then compound 4.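

In this assay the identity of the group on this phenyl counts, not only its presence: trifluoromethyl in place of chloro gives a 5.0-fold higher number from compound 2 to compound 4 (0.70 log units; beyond the scatter) and trifluoromethyl in place of hydrogen gives a 25-fold higher number from compound 1 to compound 4 (1.40 log units; beyond the scatter) as the largest step among these compounds. Set against the 3-chlorophenyl, the 2-(trifluoromethyl)phenyl gives a 10-fold higher number from compound 3 to compound 4 (1.00 log units; beyond the scatter) and leaves compound 4 with the highest number of the four. No measurement shown here explains these rises.

Still open, from the compounds shown here alone, is how trifluoromethyl reads where compound 3 carries its chloro. Also open, going by these compounds, is whether a methoxy, a fluoro or an amine on this phenyl would stay as close to compound 1 as compound 3 does.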